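A few compounds are considered here, and "the series" means these few. Any claim that something is new, unique, unknown or untested is made for them only; others in the source may bear on it.

Measured so far:
Compound 1, `COc1cc(-n2ncnc2-c2ccc(C)cc2)cc(OC)c1OC`, in a functional assay on HL-60 cells (Homo sapiens) for antiproliferative activity, read by MTT assay, with a stated time of 72 h (on this read-out higher numbers stand for weaker inhibition and lower numbers for stronger inhibition), gives 90 nM.
Compound 2, `COc1cc(-c2ncnn2-c2ccc(Cl)c(Cl)c2)cc(OC)c1OC`, in this assay reaches only a limit of the assay, > 10000 nM.

Of the two values at hand, compound 2 stands at the limit of > 10000 nM in this assay, at which 1 of the 2 values shown sits, so no number for it is known, only that its inhibition is too weak to register. Among the measured compounds shown here, compound 1 and compound 2 differ in more than one place, so no single step between them can be read; their values show only that one inhibits strongly and the other is not measurable.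

Compound 3, `COc1cc(-c2ncnn2-c2ccc(Cl)cc2)cc(OC)c1OC`, is not yet measured. It differs from compound 2 by hydrogen in place of chloro on an aromatic carbon. With compound 2 sitting at a limit, the size of the step to compound 3 in this assay cannot be fixed from a number; the expectation is a move toward stronger inhibition, possibly beyond the scatter, but with a fair chance that compound 3 also only reaches a limit. Compound 3 is estimated at 3000 nM, with a range from 500 nM to 20000 nM. This estimate implies a step of an at least 3.3-fold lower number from compound 2 to compound 3 (0.52 log units; beyond the scatter), expected rather than measured.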

Compound 3, half-maximal inhibitory concentration: > 10000 nM
Compound 3 was reported as a limit (the forecaster's own chance of this, stated with the estimate: 40%); middle value at least 3.3-fold (0.52 log units) away from the limit.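

Among the compounds shown here, compound 2 and compound 3 each reach only a limit in this assay, so no step between them can be read: the limit of > 10000 nM in this assay, at which 2 of the 3 values shown sit.

On these data alone, whether going from 3,4-dichlorophenyl to 4-chlorophenyl alters inhibition at all stays open, as neither compound has a numerical value that would show the size or direction of such a change.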